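This account rests on a few compounds, and the source may have more. Where it says the series, first, only, none or still open, it means among the compounds named here.

Compound 1, `COc1cc(N)c(Cl)cc1C(=O)NC1CCN(CCCCCN2CCCCC2)CC1`, in a functional assay on HEK293 cells for activation of 5-hydroxytryptamine receptor 4 (Homo sapiens), read by cAMP accumulation (on this read-out lower numbers stand for smaller maximal responses and higher numbers for larger maximal responses), gives > 100%, which is a limit of the assay. Compound 2, `COc1cc(N)c(Cl)cc1C(=O)NC1CCN(CCCCCCCCN2CCCCC2)CC1`, gives > 100%, again a limit. Compound 3, `COc1cc(N)c(Cl)cc1C(=O)NC1CCN(CCCCCN2CCN(S(C)(=O)=O)CC2)CC1`, gives > 100%, also a limit.

All three therefore sit at the limit of > 100% in this assay, at which 3 of the 3 values shown sit. The change 3-(piperidin-1-yl)propyl in place of piperidin-1-yl on a saturated chain carbon, five bonds along the chain from an amine nitrogen in a ring gives a step that the two limits leave unreadable from compound 1 to compound 2. The change 4-(methylsulfonyl)piperazin-1-yl in place of piperidin-1-yl on a saturated chain carbon, five bonds along the chain from an amine nitrogen in a ring gives a step that the two limits leave unreadable from compound 1 to compound 3. Between compound 2 and compound 3 the step is a step that the two limits leave unreadable from compound 2 to compound 3.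

Compound 4, `COc1cc(N)c(Cl)cc1C(=O)NC1CCN(CCCCCCCCN2CCN(S(C)(=O)=O)CC2)CC1`, is not yet measured. It differs from compound 2 by 4-(methylsulfonyl)piperazin-1-yl in place of piperidin-1-yl on a saturated chain carbon, eight bonds along the chain from an amine nitrogen in a ring. This is the same kind of change as 4-(methylsulfonyl)piperazin-1-yl in place of piperidin-1-yl on a saturated chain carbon, five bonds along the chain from an amine nitrogen in a ring, though not the same: there it sits five bonds along the chain from an amine nitrogen in a ring, here eight bonds along the chain from an amine nitrogen in a ring. The two cores differ by 3-(piperidin-1-yl)propyl in place of piperidin-1-yl on a saturated chain carbon, five bonds along the chain from an amine nitrogen in a ring. Beside a step that the two limits leave unreadable from compound 1 to compound 3, the step from compound 2 to compound 4 is expected to be a step that the limit leaves unreadable from compound 2 to compound 4, resting on compound 2 standing at > 100% and compound 3 at > 100%. Compound 4 is thus estimated at 105%, between 88% and 125%.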

Compound 4, intrinsic activity: the largest response reached, in percent of the reference agonist's: > 100%
Compound 4: a limit, no number; the forecaster's own chance of this, stated with the estimate: 70%; the middle value lies beyond the limit too.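

In this assay compound 4 gives > 100% and this is a limit of the assay. The step from compound 2 to compound 4 therefore cannot be read, and all four compounds stand at the same limit: the limit of > 100% in this assay, at which 4 of the 4 values shown sit. The compounds shown leave open how large each maximal response is, and whether 4-(methylsulfonyl)piperazin-1-yl in place of piperidin-1-yl changes it at all.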